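The source may hold more compounds than are shown below. What is called first, only, known or untested is meant among the compounds shown, and "the series" means these compounds.

Of the compounds shown here, three have so far been measured in an assay on mitochondria (strain BALB/c) for inhibition of glycerol-3-phosphate acyltransferase 1, mitochondrial (Mus musculus), read by scintillation counting, with a stated time of 10 min; a lower number here means a stronger inhibitor, a higher number a weaker inhibitor. Compound 1 `CCCCCCCCS(=O)(=O)Nc1cc(-c2ccc(Cl)cc2)ccc1C(=O)O` gives 18100 nM, compound 2 `CCCCCCCCS(=O)(=O)Nc1cc(-c2ccc(-c3ccccc3)cc2)ccc1C(=O)O` gives 13500 nM, and compound 3 `CCCCCCCCS(=O)(=O)Nc1ccc(-c2ccccc2Cl)cc1C(=O)O` gives 14400 nM. Compound 2 differs from compound 1 by phenyl in place of chloro on an aromatic carbon, and that change made a 1.3-fold lower number from compound 1 to compound 2 (0.13 log units; within the scatter). Compound 3 has the same atoms as compound 1 joined differently; the difference between the two cores is not broken down here. Compound 4 `CCCCCCCCS(=O)(=O)Nc1ccc(-c2ccccc2-c2ccccc2)cc1C(=O)O` is not yet measured and differs from compound 3 by phenyl in place of chloro on an aromatic carbon. Within the data shown here, this is the same kind of change as the one between compound 1 and compound 2, but the place is not the same: there the entering group sits para to a large group, here ortho to a large group. In this assay compound 4 is expected to show a 1.3-fold lower number from compound 3 to compound 4 (0.12 log units; within the scatter), roughly the size of a 1.3-fold lower number from compound 1 to compound 2 (0.13 log units; within the scatter), because compound 3 sits at 14400 nM close to compound 1 at 18100 nM. The estimate for compound 4 is 11000 nM, within a range of 5000 nM to 25000 nM.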

Compound 4, half-maximal inhibitory concentration: 10100 nM
Compound 4: middle estimate off by 1.1-fold (0.04 log units), on the high side; the measured number falls inside the stated range.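

In this assay, phenyl in place of chloro gives a 1.4-fold lower number from compound 3 to compound 4 (0.15 log units; within the scatter). Set side by side, the steps on the two cores agree: the same change on two cores in this assay, a 1.3-fold lower number (0.13 log units; within the scatter) from compound 1 to compound 2 and a 1.4-fold lower number (0.15 log units; within the scatter) from compound 3 to compound 4, 1.1-fold (0.03 log units) apart, within the scatter of two such steps. The change therefore carries across these two cores in a limited sense: neither step rises above the scatter, but steps this small do not show that phenyl truly improves inhibition, nor that a larger effect would carry over in the same way.

The compounds shown leave open whether an amine or a nitrile in place of chloro would give a step beyond the scatter. They also leave open how a shorter chain on the sulfonyl group would behave.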